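The source may hold more compounds than are shown below. What is called first, only, known or untested is meant among the compounds shown, and "the series" means these compounds.

Of the compounds shown here, three have been measured in a functional assay on the whole organism with Mus musculus as the target; a higher number here means a larger maximal response, a lower number a smaller maximal response. Compound 1, `CCCn1c(=O)n(C2CCC(COC(C)=O)O2)c2nc(NC(C)=O)nc(O)c21`, gives 11%. Compound 2, `C=CCn1c(=O)n([C@H]2CO[C@@H](CO)C2)c2nc(N)nc(O)c21`, gives 16%. Compound 3, `CN(C)CCCn1c(=O)n(C2OC(CO)[C@@H](O)[C@H]2O)c2nc(N)nc(O)c21`, gives 63%. On these numbers compound 3 stands highest of the three: the numbers of compound 2 and of compound 1 are both lower, and both gaps lie beyond the usual scatter of repeated measurements. Going by the values given here, no pair among the measured compounds differs in a single place, so no step has been worked out; compounds 1 and 2 each differ from compound 3 in the chain on the aromatic nitrogen and elsewhere at the same time.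

Compound 4, `CCCCn1c(=O)n(C2OC(CO)[C@@H](O)[C@H]2O)c2nc(N)nc(O)c21`, is not yet measured. Against compound 3 the change is methyl in place of dimethylamino on a saturated chain carbon, three bonds along the chain from an aromatic nitrogen. Among the compounds with values here, no measured step of this kind exists. Within the data shown here, what the three numbers show is that the one compound carrying a dimethylamino on its chain, compound 3 with 63%, lies well above the two compounds without it, though those two also differ from compound 3 elsewhere, so compounds 1 and 2 are only weak support for such a pattern. The step of a number 33 percentage points lower from compound 3 to compound 4 (beyond the scatter) is expected to be a fall beyond the scatter. Compound 4 is expected to give 30% in this assay, with a range from 10% to 60%.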

Compound 4, largest response reached (reported as maximal response), in percent of the reference or control that the assay uses: 70%
Estimate against measurement, compound 4: 40 percentage points below; measured number above the stated range.
By their numbers in this assay, from the lowest: compounds 1 and 2 (each within the scatter of the next); then compounds 3 and 4 (each within the scatter of the next).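

In this assay the single-place change of methyl in place of dimethylamino, on a saturated chain carbon three bonds along the chain from an aromatic nitrogen, gives a number 7 percentage points higher from compound 3 to compound 4 (within the scatter). The change from 3-(dimethylamino)propyl to butyl therefore does not separate these two compounds, and the earlier link between a dimethylamino on the chain and a high number does not hold, with compound 4 going against it as a compound without that group whose value lies within the scatter of compound 3. No measured information on either compound offers an explanation for this result.

From the compounds shown here alone, the effect of a carboxylic acid or a primary amine in place of dimethylamino at this chain carbon, or of a longer chain such as hexyl, remains open. Compounds 1 and 2 each differ from compound 3 and compound 4 in more than one place, so it also remains open which of those places accounts for their lower numbers.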